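Compound 3 to compound 4: a new amine substituent

The source may hold more compounds than are shown below. What is called first, only, known or untested is meant among the compounds shown, and "the series" means these compounds.

Measured so far:
- compound 1 `COc1c([C@H](C)Nc2ncnc3[nH]cnc23)cc(Cl)c(C)c1-c1ccc(S(C)(=O)=O)cc1` gives 170 nM
- compound 2 `COc1c([C@H](C)Nc2ncnc(N)c2C#N)cc(Cl)c(C)c1-c1ccc(C(=O)N(C)C)cn1` gives 21 nM
- compound 3 `COc1c([C@H](C)Nc2ncnc3[nH]cnc23)cc(Cl)c(C)c1-c1cncc(S(C)(=O)=O)c1` gives 14 nM

All three values come from a functional assay on SU-DHL-6 cells (Homo sapiens) for cytotoxicity, read by luminescence, with a stated time of 4 days (a lower number here means a stronger inhibitor, a higher number a weaker inhibitor), and are the basis for these notes. Compound 3 at 14 nM lies within the scatter of compound 2 and well under compound 1.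

Compound 4 `COc1c([C@H](C)Nc2ncnc(N)c2C#N)cc(Cl)c(C)c1-c1cncc(S(C)(=O)=O)c1` keeps the 5-(methylsulfonyl)pyridin-3-yl of compound 3 and changes only the group on an amine nitrogen: a group of 9 heavy atoms (5 carbon, 4 nitrogen; one six-membered aromatic ring with 2 hetero atoms) in place of a group of 9 heavy atoms (5 carbon, 4 nitrogen; one five-membered aromatic ring with 2 hetero atoms, one six-membered aromatic ring with 2 hetero atoms), on an amine nitrogen brings in 6-amino-5-cyanopyrimidin-4-yl.

Among the measured compounds shown here, the one measured step, a 12-fold lower number from compound 1 to compound 3 (1.08 log units; beyond the scatter), is large but lies at a different place, on an aromatic carbon, so it does not size this change. For the measured compounds named here, no measured pair isolates the swap. Compound 2 already carries 6-amino-5-cyanopyrimidin-4-yl and gives 21 nM in this assay, although it also differs on the aromatic carbon. The step expected in this assay is therefore a 1.1-fold higher number from compound 3 to compound 4 (0.03 log units; within the scatter) and so none beyond the scatter. Compound 4 is estimated at 15 nM (expected range 5 nM to 45 nM).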

Compound 4, half-maximal inhibitory concentration: 3.1 nM
Compound 4: middle estimate off by 4.8-fold (0.68 log units), on the high side, outside the stated range (below it).
By their numbers in this assay, from the lowest: compound 4; then compounds 3 and 2 (each within the scatter of the next); then compound 1.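

In this assay the group on the amine nitrogen now has a step of its own: with 5-(methylsulfonyl)pyridin-3-yl held fixed, 6-amino-5-cyanopyrimidin-4-yl gives a 4.5-fold lower number from compound 3 to compound 4 (0.65 log units; beyond the scatter) and so moves the number beyond the scatter. On the aromatic carbon, 5-(methylsulfonyl)pyridin-3-yl lowers the number with this new amine substituent, a 6.8-fold lower number from compound 2 to compound 4 (0.83 log units; beyond the scatter) in that case, just as it did with the earlier substituent, a 12-fold lower number from compound 1 to compound 3 (1.08 log units; beyond the scatter) in that case, and no pair shown runs against this. No measurement shown here bears on what lies behind these steps.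

Still open, going by these compounds, is whether 6-amino-5-cyanopyrimidin-4-yl gives a similar step with 4-(methylsulfonyl)phenyl or 5-(dimethylcarbamoyl)pyridin-2-yl on the aromatic carbon. Also open, on these data alone, is how a carboxylic acid or a morpholine in place of the methylsulfonyl would read in this assay with this amine substituent.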